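Lysine series: benzyl ester to free acid

The source may report more compounds than this note shows. Statements on the series, on what has been measured and on what is new or still open speak of the compounds shown alone.

Two compounds have been run so far in a functional assay on the whole organism (Tail, strain ICR) with Mus musculus as the target, in the tail flick test, with a stated time of 30 min, at a dose of 25 umol/kg by the oral route; on this read-out higher numbers stand for a stronger effect at the one dose given and lower numbers for a weaker effect. Compound 1 `CC[C@H](C)[C@H](NC(=O)CN(c1nc(Cl)nc2[nH]cnc12)C1CC1)C(=O)O` carries a free carboxylic acid and in this assay compound 1 gives 30.3%. Compound 2 `NCCCC[C@H](NC(=O)CN(c1nc(Cl)nc2[nH]cnc12)C1CC1)C(=O)OCc1ccccc1` is the benzyl ester of the lysine analogue, and in this assay compound 2 gives 26.1%. Going by the values given here, the two numbers lie within the scatter of each other, so compound 2 cannot be set apart from compound 1 on this read-out; no step between them can be read as real.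

Compound 3 `NCCCC[C@H](NC(=O)CN(c1nc(Cl)nc2[nH]cnc12)C1CC1)C(=O)O` has not yet been measured. It differs from compound 2 in one place: hydrogen in place of benzyl on an oxygen next to a carbonyl group. The only free acid already measured, compound 1, sits within the scatter of the ester compound 2, which gives no ground for expecting a shift in either direction beyond the scatter.

For this assay the estimated step from compound 2 to compound 3 is expected to be a number 1.9 percentage points higher from compound 2 to compound 3 (within the scatter). Compound 3 is accordingly expected to give about 28% in this assay, with a range from 12% to 45%.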

Compound 3, a percentage reported as activity, at one dose (the size of the read-out at that dose, not a potency): 31.2%
Beside the measured number, compound 3's estimate is 3.2 percentage points below it; the measured number falls inside the stated range.
By their numbers in this assay, from the lowest: compounds 2, 1 and 3 (each within the scatter of the next).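

In this assay, hydrogen in place of benzyl on an oxygen next to a carbonyl group gives a number 5.1 percentage points higher from compound 2 to compound 3 (within the scatter), so on the lysine compounds this read-out does not separate the benzyl ester from the free carboxylic acid at the one dose given. Going by these compounds alone, with the free acid held constant, 4-aminobutyl in place of sec-butyl on a saturated chain carbon bound to an amide-type nitrogen and a carbonyl carbon gives a number 0.9 percentage points higher from compound 1 to compound 3 (within the scatter), the first single-place comparison of these two side chains, and it cannot be read as a real difference either. No measurement available here bears on why neither change separates the compounds.

The compounds shown leave open whether a smaller ester such as a methyl ester, or a primary amide in place of the carboxylic acid, would give a step beyond the scatter. They also leave open whether a shorter or longer aminoalkyl chain, or a guanidine in place of the terminal amine, would separate from compound 3 in this assay.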